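Cyclopentyl for propyl on the amide of compound 1

The compounds below may be only part of what the source reports. "The series", "measured", "known", "first", "only" and "open" are said of these compounds alone.

- compound 1 `CCCNC(=O)c1ccc2c(ccn2-c2ncc3c(n2)N(c2ccn(C)n2)C(CC)C(=O)N3C)c1` gives 6160 nM
- compound 2 `CCCNC(=O)c1ccc2c(ccn2-c2ncc3c(n2)N(C2CCCC2)[C@H](CC)C(=O)N3C)c1` gives 238 nM

Both values come from a functional assay on HeLa cells (Homo sapiens) for antiproliferative activity, read by CCK-8 assay, with a stated time of 72 h (on this read-out higher numbers stand for weaker inhibition of growth and lower numbers for stronger inhibition of growth), and no other read-out is available. Compound 1 has the higher number of the two, and its gap to compound 2 lies beyond the scatter.

The next compound to be tested, compound 3 `CCC1C(=O)N(C)c2cnc(-n3ccc4cc(C(=O)NC5CCCC5)ccc43)nc2N1c1ccn(C)n1`, keeps the core of compound 1 and changes only the amide substituent: cyclopentyl in place of propyl on an amide-type nitrogen, which is cyclopentyl in place of propyl on an amide-type nitrogen. Within the data shown here, no measured pair shows this change alone, and compound 2 differs from compound 1 in another place, so the two values give no size for it.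

In this assay no step beyond the scatter is expected, only a slight lean towards a lower number. The estimated step is a 1.4-fold lower number from compound 1 to compound 3 (0.14 log units; within the scatter) and it is expected to stay within the scatter. Compound 3 is estimated at 4500 nM with an expected range from 1300 nM to 14000 nM in this read-out.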

Compound 3, concentration for 50% growth inhibition: 27400 nM
For compound 3 the middle estimate is 6.1-fold (0.78 log units) below the measured one; measured number above the stated range.
By their numbers in this assay, from the lowest: compound 2; then compound 1; then compound 3.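

In this assay, cyclopentyl in place of propyl on the amide-type nitrogen gives a 4.4-fold higher number from compound 1 to compound 3 (0.65 log units; beyond the scatter), the first size available for any change at this position. On the core of compound 1, this position therefore does not tolerate every carbon-only substituent equally: the change adds no hydrogen-bond donor or acceptor and no net charge, yet growth inhibition is weaker with cyclopentyl than with propyl. The data give no measured basis for explaining this step.

The compounds shown leave open whether the step follows the ring itself or the added carbons, a question that an open chain such as butyl or a branched group such as isopropyl on the same nitrogen would address, and whether a shorter chain such as ethyl would move the number the other way. They also leave open whether the step carries over to the core of compound 2, which differs from compound 1 in another place and so gives no size for this change.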